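A furan-2-yl to 1,3-oxazol-2-yl swap, estimated

The compounds below may be only part of what the source reports. "The series", "measured", "known", "first", "only" and "open" are said of these compounds alone.

Three compounds that share a core have numbers in a functional assay on MCF7 cells (Homo sapiens) for inhibition, with a stated time of 96 h; on this read-out lower numbers stand for stronger inhibition and higher numbers for weaker inhibition. Compound 1 `COc1cc(C(=O)c2cn(-c3ccc(C)cc3)cc2-c2ccco2)cc(OC)c1OC` gives 22 nM, compound 2 `COc1cc(C(=O)c2cn(-c3ccc(C)cc3)cc2-c2ncco2)cc(OC)c1OC` gives 42 nM, and compound 3 `COc1cc(C(=O)c2cn(-c3ccc(F)cc3)cc2-c2ccco2)cc(OC)c1OC` gives 17 nM. Compound 3 stands within the scatter of compound 1 and clearly below compound 2.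

Compound 4 `COc1cc(C(=O)c2cn(-c3ccc(F)cc3)cc2-c2ncco2)cc(OC)c1OC` differs from compound 3 in one place: 1,3-oxazol-2-yl in place of furan-2-yl on an aromatic carbon. There, 1,3-oxazol-2-yl takes the place of furan-2-yl on an aromatic carbon of a five-membered aromatic ring with 1 nitrogen.

The same exchange has been measured only once, a 1.9-fold higher number from compound 1 to compound 2 (0.28 log units; within the scatter), and that step lies within the scatter. The change from methyl to fluoro, a 1.3-fold lower number from compound 1 to compound 3 (0.11 log units; within the scatter), also lies within the scatter, so the two compounds offer a fair comparison for carrying the exchange across. Resting on that single exchange, the expected step is a 1.9-fold higher number from compound 3 to compound 4 (0.27 log units; within the scatter), a modest rise that would not clearly leave the scatter. For compound 4 the estimated value is 32 nM, with an expected range from 15 nM to 70 nM.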

Compound 4, half-maximal inhibitory concentration: 93 nM
For compound 4 the middle estimate is 2.9-fold (0.46 log units) below the measured one; the whole stated range lies below it.
By their numbers in this assay, from the lowest: compounds 3, 1 and 2 (each within the scatter of the next, the first and the last beyond it); then compound 4.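

With a fluoro group in place of methyl, the same exchange of furan-2-yl for 1,3-oxazol-2-yl gives a 5.5-fold higher number from compound 3 to compound 4 (0.74 log units; beyond the scatter), so its cost at this position depends on the rest of the molecule. Read the other way, fluoro in place of methyl, which stayed within the scatter on the furan-2-yl compounds, gives a 2.2-fold higher number from compound 2 to compound 4 (0.35 log units; beyond the scatter) on the 1,3-oxazol-2-yl compounds. The two changes therefore do not simply add up, and each step has to be read together with the other group present: the same change on two cores in this assay, a 1.9-fold higher number (0.28 log units; within the scatter) from compound 1 to compound 2 and a 5.5-fold higher number (0.74 log units; beyond the scatter) from compound 3 to compound 4, 2.9-fold (0.46 log units) apart, beyond the scatter of two such steps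

Among these compounds, these four compounds do not show why the two groups interact, since they cover only two groups at each of the two places. Going by these compounds, whether the same dependence holds with a methoxy group or an amine in place of fluoro, or with thiophen-2-yl in place of furan-2-yl, remains open.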